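A few compounds are considered here, and "the series" means these few. Any claim that something is new, unique, unknown or untested is made for them only; others in the source may bear on it.

Among the measured compounds shown here, in a functional assay on MCF7 cells (Homo sapiens) for antiproliferative activity, read by sulforhodamine B assay, with a stated time of 72 h (on this read-out higher numbers stand for weaker inhibition and lower numbers for stronger inhibition), compound 1 (`COc1ccc(/C=C2\CCC=CC2=O)cc1`) gives 2570 nM and compound 2 (`COc1ccc(/C=C2\CCC=CC2=O)c(C)c1`) gives 1840 nM, so compound 1 stands within the scatter of the only other measured compound. Compound 3 (`O=C1C=CCC/C1=C\c1ccc(-c2ccccc2)cc1`) has phenyl in place of methoxy on an aromatic carbon. For the measured compounds named here, the only measured step, a 1.4-fold lower number from compound 1 to compound 2 (0.15 log units; within the scatter), is methyl in place of hydrogen on an aromatic carbon, a different change, so it offers only weak guidance. No step beyond the scatter is therefore expected in this assay. The expected step is a 1.2-fold higher number from compound 1 to compound 3 (0.07 log units; within the scatter). For compound 3 the estimate is 3000 nM, with the value expected between 900 nM and 10000 nM.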

Compound 3, half-maximal inhibitory concentration: 4970 nM
Compound 3: middle estimate off by 1.7-fold (0.22 log units), on the low side, within the range that was stated.
By their numbers in this assay, from the lowest: compounds 2, 1 and 3 (each within the scatter of the next, the first and the last beyond it).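

In this assay, phenyl in place of methoxy gives a 1.9-fold higher number from compound 1 to compound 3 (0.29 log units; within the scatter), so this position, on an aromatic carbon para to a group of 8 heavy atoms, accepts a six-membered aromatic ring of carbon only with no step beyond the scatter. The earlier step, methyl in place of hydrogen, did not touch this position. No data at hand bear on why this step has the size it has. From the compounds shown here alone, whether an amine or a carboxylic acid here would also stay within the scatter of compound 1 remains open.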